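The source may report more compounds than this note shows. Statements on the series, on what has been measured and on what is new or still open speak of the compounds shown alone.

Two compounds of the series have so far been run in an assay on tissue (RPTEC cells) for inhibition of solute carrier family 22 member 12 (Homo sapiens), read by scintillation counting, with stated times of 15 min and 2 h; a lower number here means a stronger inhibitor, a higher number a weaker inhibitor. Compound 1 `COc1cc(C(=O)N2CCc3ccccc32)cc(C#N)c1O` gives > 100000 nM, which is a limit of the assay and not a number. Compound 2 `N#Cc1cc(C(=O)N2CCc3ccccc32)cc(C#N)c1O` gives 83900 nM in this assay. Going by the values given here, the single measured step, an at least 1.1-fold lower number from compound 1 to compound 2 (0.07 log units; that floor lies within the scatter), is the only guide to the series, and its floor is set by the limit of > 100000 nM in this assay, at which 1 of the 2 values shown sits, so it says little about direction. Among the compounds with values here, compound 2 thus stands as the only compound with an actual number, and that number places it among weak inhibitors.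

Compound 3 `CSc1cc(C(=O)N2CCc3ccccc32)cc(C#N)c1O` differs from compound 2 by methylsulfanyl in place of cyano on an aromatic carbon. Within the data shown here, no measured step swaps a cyano for a methylsulfanyl; the nearest comparison is the exchange of methoxy for cyano, which moved the number by an at least 1.1-fold lower number from compound 1 to compound 2 (0.07 log units; that floor lies within the scatter), a change that does not rise above the scatter. The expectation for compound 3 in this assay is therefore a step of a 1.8-fold higher number from compound 2 to compound 3 (0.25 log units; within the scatter), with a real chance that the assay again reports only a limit. The estimate for compound 3 is 150000 nM, between 40000 nM and 600000 nM.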

Compound 3, half-maximal inhibitory concentration: > 100000 nM
Compound 3: no number, only a limit (the forecaster's own chance of this, stated with the estimate: 55%); the middle value does not contradict the limit.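

Going by these compounds alone, at the place ortho to a hydroxy group, methylsulfanyl in place of cyano gives in this assay an at least 1.1-fold higher number from compound 2 to compound 3 (0.07 log units; that floor lies within the scatter) and so, like the exchange of methoxy for cyano, shows no step that stands clear of the scatter. In the same assay compound 3 gives > 100000 nM and this is a limit, not a number. The step between the methoxy and methylsulfanyl compounds cannot be read, and of the three groups tried at this place only cyano comes with a number, so what the series can say about this position ends at the limit: the limit of > 100000 nM in this assay, at which 2 of the 3 values shown sit.

On these data alone, it remains open whether any group at this place, such as an amine, a carboxylic acid or a longer chain in place of methylsulfanyl, would bring the number clearly down from the weak range of compound 2. Also open, as far as these compounds go, is whether changes elsewhere on the shared core, at the hydroxy group or the remaining cyano group, would matter more than this exchange.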